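Second methyl on the aryl amide of compound 2

The source may hold more compounds than are shown below. What is called first, only, known or untested is meant among the compounds shown, and "the series" means these compounds.

Of the compounds shown here, two have so far been measured in an assay on NIH3T3 cells with Urotensin-2 receptor (Homo sapiens) as the target; on this read-out lower numbers stand for an effect already at smaller amounts and higher numbers for an effect only at larger amounts of compound. Compound 1 `Cc1cccc(C(=O)OC(CCN(C)C)c2ccc(Cl)cc2)c1C`, an ester carrying two methyl groups on its aromatic ring, gives 1150 nM. Compound 2 `Cc1ccccc1C(=O)NC(CCN(C)C)c1ccc(Cl)cc1`, the amide with a single methyl on that ring, gives 3550 nM and thus stands at the higher of the two numbers, its distance to compound 1 lying beyond the usual scatter. Compound 2 and compound 1 differ in two places at once, so the two values show only that the ester with two methyl groups sits lower than the amide with one.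

Compound 3 `Cc1ccc(C(=O)NC(CCN(C)C)c2ccc(Cl)cc2)c(C)c1` keeps the amide of compound 2 and differs from it in one place: methyl in place of hydrogen on an aromatic carbon. For the measured compounds named here, no step between measured compounds of this kind is available, so the size of the expected effect in this assay rests on analogy alone. Because compound 1 gives 1150 nM with a second methyl present, a modest move toward lower numbers appears plausible for compound 3, though it could also stay within the scatter. Compound 3 is therefore expected to give 2200 nM, within a range of 900 nM to 5500 nM, which is a step of a 1.6-fold lower number from compound 2 to compound 3 (0.21 log units; within the scatter) by estimate.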

Compound 3, half-maximal effective concentration: 1550 nM
Compound 3: middle estimate off by 1.4-fold (0.15 log units), on the high side, and the stated range covers the measured number.
By their numbers in this assay, from the lowest: compounds 1 and 3 (each within the scatter of the next); then compound 2.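

In this assay, for the compounds shown here, the added methyl gives the first step that can be read at a single place, a 2.3-fold lower number from compound 2 to compound 3 (0.36 log units; beyond the scatter), and it shows that this one change, small as it is, moves the number by more than the usual scatter. The position concerned is the aromatic carbon meta to the methyl group already present and para to the large group, so the change from 2-methylphenyl to 2,4-dimethylphenyl keeps the amide intact and shifts the read-out toward an effect at smaller amounts of compound. Nothing available explains why this methyl has this effect.

On these data alone, it remains open whether the gain belongs to methyl itself or whether an ethyl group, a methoxy group or a chlorine atom on the same carbon would give a step of similar size, or a larger one. As far as these compounds go, it is equally open whether a methyl on another carbon of this ring would match the step, and whether the same change would carry over to an ester such as compound 1.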